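The compounds below may be only part of what the source reports. "The series", "measured", "known", "first", "only" and "open" are said of these compounds alone.

Compound 1, `CC(C)CS(=O)(=O)N(Cc1ccc(-c2cccc(F)c2F)cc1)[C@@H](C)C(=O)N[C@H](C#N)CC(N)=O`, gives 1820 nM in an assay on isolated protein for inhibition of legumain (Homo sapiens), with stated times of 2 min and 60 min; on this read-out lower numbers stand for stronger inhibition and higher numbers for weaker inhibition.
Compound 2, `CC(C)CS(=O)(=O)N(Cc1ccc(-c2cccc(F)c2)cc1)[C@@H](C)C(=O)N[C@H](C#N)CC(N)=O`, gives 2270 nM in this assay.

Compound 2 carries the higher of the two numbers shown, but the only measured step, a 1.2-fold higher number from compound 1 to compound 2 (0.10 log units; within the scatter), lies within the scatter, so the two compounds cannot be told apart on this read-out. Compound 3, `CCCS(=O)(=O)N(Cc1ccc(-c2cccc(F)c2)cc1)[C@@H](C)C(=O)N[C@H](C#N)CC(N)=O`, is built from compound 2 by a single change: hydrogen in place of methyl on a saturated chain carbon bound to two saturated chain carbons. Put another way, the isobutylsulfonyl group of compound 2 becomes a propylsulfonyl group in compound 3. Among the measured compounds shown here, no measured step touches this part of the molecule; the one step known concerns a fluoro on an aromatic carbon and is itself within the scatter. The data therefore give no basis for expecting a large shift in either direction, and the expected step of a 1.2-fold higher number from compound 2 to compound 3 (0.08 log units; within the scatter) is kept small, leaning only slightly toward a higher number. Compound 3 is estimated to give about 2700 nM in this assay, with a range from 1100 nM to 6500 nM.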

Compound 3, half-maximal inhibitory concentration: > 10000 nM
Compound 3 ended at the assay's limit; the forecaster's own chance of this, stated with the estimate: 3%; middle value at least 3.7-fold (0.56 log units) from the limit.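

Going from isobutylsulfonyl to propylsulfonyl removes only one methyl, yet it gives an at least 4.4-fold higher number from compound 2 to compound 3 (0.64 log units; beyond the scatter), so this side chain is far less forgiving than the fluoro position, where the only earlier step stayed within the scatter. In this assay, compound 3 gives > 10000 nM, which is a limit of the assay and not a number. The size of the step is therefore only a lower bound, and the true loss of inhibition could be larger: the limit of > 10000 nM in this assay, at which 1 of the 3 values shown sits.

With a single change at this position, the compounds shown cannot separate the loss of the branch from the shortening of the chain; a straight butylsulfonyl group, which would lack the branch without being shorter than the isobutyl chain, would help to tell these two readings apart. Also open, as far as these compounds go, are whether a longer chain such as pentyl would restore inhibition, and whether the same methyl removal would have a similar effect on the core of compound 1, with its extra fluoro.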